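The source may hold more compounds than are shown below. What is called first, only, known or untested is meant among the compounds shown, and "the series" means these compounds.

In an ADME assay on MRC5 cells (Homo sapiens) for cytotoxicity, read by neutral red uptake (a higher number here means that more compound is tolerated, a lower number that less compound is tolerated), compound 2 (`O=c1[nH]c(SCc2cc([N+](=O)[O-])cc([N+](=O)[O-])c2)nc2ccc(N3CCCCC3)cc12`) gives > 64000 nM, which is a limit of the assay and not a number. Compound 1 (`O=c1[nH]c(SCc2cc([N+](=O)[O-])cc([N+](=O)[O-])c2)nc2ccc(F)cc12`) gives > 64000 nM, which is also a limit. The whole record so far is the limit of > 64000 nM in this assay, at which 2 of the 2 values shown sit. Compound 3 (`CN1CCN(c2ccc3nc(SCc4cc([N+](=O)[O-])cc([N+](=O)[O-])c4)[nH]c(=O)c3c2)CC1`) has 4-methylpiperazin-1-yl in place of piperidin-1-yl on an aromatic carbon of the shared core: 4-methylpiperazin-1-yl in place of piperidin-1-yl on an aromatic carbon. Among the measured compounds shown here, the only measured step that bears on this change is a step that the two limits leave unreadable from compound 1 to compound 2, where piperidin-1-yl took the place of fluoro on that aromatic carbon. That step offers no size to carry over, so no step beyond the scatter is expected in this assay, in either direction. The expected move is an at least 1.1-fold lower number from compound 2 to compound 3 (0.06 log units; that floor lies within the scatter). The half-maximal cytotoxic concentration of compound 3 is estimated at 55000 nM, with an expected range of 25000 nM to 64000 nM.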

Compound 3, half-maximal cytotoxic concentration: 49000 nM
Beside the measured number, compound 3's estimate is 1.1-fold (0.05 log units) above it; low and high end bracket the measured number.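

In this assay compound 3 gives this aromatic carbon its first value that is a number and not a limit, so a change here can now be given a floor, though not an exact size. Placing 4-methylpiperazin-1-yl on this carbon shows an at least 1.3-fold lower number from compound 2 to compound 3 (0.11 log units; that floor lies within the scatter) where it replaces piperidin-1-yl, and an at least 1.3-fold lower number from compound 1 to compound 3 (0.11 log units; that floor lies within the scatter) where it replaces fluoro. Both floors stay within the scatter, and the step between compound 1 and compound 2 still cannot be read, as both of their values are limits: the limit of > 64000 nM in this assay, at which 2 of the 3 values shown sit.

The compounds shown leave open the real size of both new steps, since only their floors are known. They also leave open what a carboxylic acid or a longer chain ending in an amine would give on this aromatic carbon in this assay.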